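Tetrazole bearing a carboxymethyl arm at the biaryl position

A few compounds are considered here, and "the series" means these few. Any claim that something is new, unique, unknown or untested is made for them only; others in the source may bear on it.

Compound 1 `CC(C)(N)CC(=O)N[C@@H]1CCc2ccccc2N(Cc2ccc(-c3ccccc3C(N)=O)cc2)C1=O` sits second highest of the three numbers in hand for a functional assay (Pituitary gland cell) with Rattus norvegicus as the target; a higher number here means that more compound is needed for the effect, a lower number that less compound is needed; in it compound 1 gives 0.08 uM. Compound 2 `CC(O)Cn1nnnc1-c1ccccc1-c1ccc(CN2C(=O)[C@H](NC(=O)CC(C)(C)N)CCc3ccccc32)cc1` gives 0.05 uM, and compound 3 `CC(C)(N)CC(=O)N[C@@H]1CCc2ccccc2N(Cc2ccc(-c3ccccc3S(=O)(=O)NC(=O)c3ccccc3)cc2)C1=O` gives 3 uM. The step of a 1.6-fold lower number from compound 1 to compound 2 (0.20 log units; within the scatter) stays inside the scatter, whereas a 38-fold higher number from compound 1 to compound 3 (1.57 log units; beyond the scatter) and a 60-fold higher number from compound 2 to compound 3 (1.78 log units; beyond the scatter) are both large losses.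

Compound 4 `CC(C)(N)CC(=O)N[C@@H]1CCc2ccccc2N(Cc2ccc(-c3ccccc3-c3nnn(CC(=O)O)n3)cc2)C1=O` differs from compound 1 in one place: 2-(carboxymethyl)-2H-tetrazol-5-yl in place of carbamoyl on an aromatic carbon. Going by the values given here, two measured steps bear on this. Compound 2 shows that a five-membered aromatic ring with 4 hetero atoms in this position is tolerated, the step of a 1.6-fold lower number from compound 1 to compound 2 (0.20 log units; within the scatter) being within the scatter. Compound 3 shows that a bulkier group carrying an extra hydrogen-bond donor and several acceptors can cost a great deal, the step of a 38-fold higher number from compound 1 to compound 3 (1.57 log units; beyond the scatter) being far beyond the scatter. The new group in compound 4 shares the ring of compound 2 but adds the carboxymethyl arm, so a moderate loss in this assay is expected, smaller than the loss seen for compound 3 because of a 38-fold higher number from compound 1 to compound 3 (1.57 log units; beyond the scatter), the estimated step being a 3.8-fold higher number from compound 1 to compound 4 (0.57 log units; beyond the scatter). Compound 4 is therefore estimated at 0.3 uM, with a range of 0.06 uM to 2 uM.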

Compound 4, concentration for half-maximal effect: 0.2 uM
The estimate for compound 4 lay 1.5-fold (0.18 log units) above the measured number, within the range that was stated.
By their numbers in this assay, from the lowest: compounds 2 and 1 (each within the scatter of the next); then compound 4; then compound 3.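

In this assay, 2-(carboxymethyl)-2H-tetrazol-5-yl in place of carbamoyl, on this aromatic carbon ortho to a large group, brings a modest shift, a 2.5-fold higher number from compound 1 to compound 4 (0.40 log units; beyond the scatter), and replacing 1-(2-hydroxypropyl)-1H-tetrazol-5-yl with it brings another, a 4.0-fold higher number from compound 2 to compound 4 (0.60 log units; beyond the scatter), so a five-membered aromatic ring with 4 hetero atoms does not alone fix the number at this position. The same group also stands well apart from benzoylsulfamoyl, a 15-fold lower number from compound 3 to compound 4 (1.18 log units; beyond the scatter), which shows that going from the 3 heavy atoms of carbamoyl to the 9 of this group does not by itself bring a loss as large as that of compound 3. No measurement in hand gives a reason for any of these differences.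

The two tetrazole groups differ both in the arm and in where it sits on the ring, so the compounds shown do not separate these two changes. Open too, going by these compounds, is how the number in this assay would respond to an unsubstituted tetrazole, a methyl ester of the carboxymethyl arm, or a longer chain ending in a carboxylic acid.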